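The compounds below may be only part of what the source reports. "The series", "measured", "known", "first", "only" and "open" are said of these compounds alone.

Compound 3 `CN(C(=O)NC(=O)c1ccc(Cl)cc1Cl)c1nc(C(F)(F)F)c(C(=O)N/N=C/c2cc(C(F)(F)F)cc(C(F)(F)F)c2)s1` stands at the top of what has been measured: in a functional assay on A549 cells (Homo sapiens) for inhibition, read by MTT assay, with a stated time of 72 h (a higher number here means a weaker inhibitor, a lower number a stronger inhibitor), compound 3 gives > 100 ug/mL, a limit rather than a number. Compound 1 `CN(C(=O)NC(=O)c1ccc(Cl)cc1Cl)c1nc(C(F)(F)F)c(C(=O)N/N=C/c2cccc(C(F)(F)F)c2)s1` gives 10.6 ug/mL in this assay. Compound 2 `CNc1nc(C)c(C(=O)N/N=C/c2cccc(C(F)(F)F)c2)s1` gives > 100 ug/mL, also a limit. For the measured compounds named here, the one measured step, an at least 9.4-fold higher number from compound 1 to compound 3 (0.97 log units; beyond the scatter), concerns a different part of the molecule; the limit of > 100 ug/mL in this assay, at which 2 of the 3 values shown sit, is reached there. Compound 4 `CN(C(=O)NC(=O)c1ccc(C(F)(F)F)cc1)c1nc(C(F)(F)F)c(C(=O)N/N=C/c2cc(C(F)(F)F)cc(C(F)(F)F)c2)s1` differs from compound 3 by 4-(trifluoromethyl)phenyl in place of 2,4-dichlorophenyl on a carbonyl carbon. No measured step touches this carbonyl substituent, so nothing shown points in either direction; compound 3 itself is already a limit. The expected step that the limit leaves unreadable from compound 3 to compound 4 is therefore small. Compound 4 is estimated at 150 ug/mL, within 40 ug/mL to 500 ug/mL, most likely again reported as a limit.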

Compound 4, half-maximal inhibitory concentration: 5.9 ug/mL
The estimate for compound 4 lay 25-fold (1.41 log units) above the measured number, outside the stated range (below it).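

The carbonyl substituent, untouched by the earlier step, turns out to govern activity in this assay: 4-(trifluoromethyl)phenyl in place of 2,4-dichlorophenyl gives an at least 16-fold lower number from compound 3 to compound 4 (1.22 log units; beyond the scatter). Compound 4 keeps the trifluoromethyl that compound 1 lacks, so that group does not by itself end activity. The value for compound 3 is a limit, so the step is only a bound: the limit of > 100 ug/mL in this assay, at which 2 of the 4 values shown sit.

Still open, going by these compounds, is whether the change follows the loss of the chlorines or the entry of trifluoromethyl, and how a plain phenyl on this carbonyl carbon would read.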